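The source may hold more compounds than are shown below. What is called first, only, known or untested is meant among the compounds shown, and "the series" means these compounds.

Compound 1 `COCc1nc(C)c2cnnc(S)n12` and compound 2 `COCc1ncc2cnnc(S)n12` share one core and differ only in hydrogen in place of methyl on an aromatic carbon. In a functional assay for inhibition, with Homo sapiens as the target (on this read-out higher numbers stand for weaker inhibition and lower numbers for stronger inhibition), compound 1 gives only a limit of the measurement, > 48000 nM. Compound 2 likewise gives only a limit in this assay, > 48000 nM. The step that the two limits leave unreadable from compound 1 to compound 2 therefore has no readable size because the limit of > 48000 nM in this assay, at which 3 of the 3 values shown sit, holds both values. Compound 3 `CCCc1nc(C)c2c(C)cnc(Nc3cc[nH]n3)n12` has a core whose difference from the core of compound 1 is not broken down here. In this assay compound 3 also gives only a limit, > 48000 nM. Compound 4 `CCCc1ncc2c(C)cnc(Nc3cc[nH]n3)n12` differs from compound 3 by hydrogen in place of methyl on an aromatic carbon. This is the same kind of change as that from compound 1 to compound 2, though the surroundings differ: there the ring atom two ring bonds away bears a methoxymethyl group, here a propyl group. Because a step that the two limits leave unreadable from compound 1 to compound 2 offers no readable size, the expected step that the limit leaves unreadable from compound 3 to compound 4 rests only on the silence of the earlier pair. Compound 4 is expected to give about 70000 nM, most likely again only a limit, within a range from 20000 nM to 300000 nM.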

Compound 4, half-maximal inhibitory concentration: 39000 nM
Compound 4: the middle estimate sits 1.8-fold (0.25 log units) above what was measured; the range from low to high includes it.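

Putting hydrogen in place of methyl on the core of compound 3 gives, in this assay, an at least 1.2-fold lower number from compound 3 to compound 4 (0.09 log units; that floor lies within the scatter). This is only a floor on the size of the step, so it neither shows that the change strengthens inhibition nor rules that out. The same change on the core of compound 1 cannot be read, so the two cores cannot be compared, and nothing shows that the change carries from one to the other, because both values of that pair sit at one limit: the limit of > 48000 nM in this assay, at which 3 of the 4 values shown sit.

On these data alone, it remains open whether an amine, a carboxylic acid or a longer chain in place of the propyl group would bring much lower numbers. As far as these compounds go, it also remains open how this change behaves on a core where both partners give readable values.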